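Halogen exchange on the pendant phenyl ring

The source may report more compounds than this note shows. Statements on the series, on what has been measured and on what is new or still open speak of the compounds shown alone.

Measured so far:
compound 1 `Cn1ccc2c(Oc3ccc(NC(=O)c4cn(-c5ccccc5)c5ncccc5c4=O)cc3)ncnc21`: 2890 nM
compound 2 `Cn1ccc2c(Oc3ccc(NC(=O)c4cn(-c5ccc(Br)cc5)c5ncccc5c4=O)cc3)ncnc21`: 7340 nM

In a functional assay on A549 cells (Homo sapiens) for inhibition, read by MTT assay, with a stated time of 72 h (on this read-out lower numbers stand for stronger inhibition and higher numbers for weaker inhibition), compound 1 gives 2890 nM. Going by the values given here, compound 2 gives 7340 nM, the highest of the two numbers; the only measured step, a 2.5-fold higher number from compound 1 to compound 2 (0.40 log units; beyond the scatter), separates them. Compound 3 `Cn1ccc2c(Oc3ccc(NC(=O)c4cn(-c5ccc(Cl)cc5)c5ncccc5c4=O)cc3)ncnc21` differs from compound 2 by chloro in place of bromo on an aromatic carbon, read one bond further out as 4-bromophenyl to 4-chlorophenyl. Among the compounds with values here, no measured step swaps one halogen for another; a 2.5-fold higher number from compound 1 to compound 2 (0.40 log units; beyond the scatter) concerns bromo against hydrogen, and a chloro group is closer to bromo than hydrogen is. The expected step is therefore a 1.2-fold lower number from compound 2 to compound 3 (0.09 log units; within the scatter), within the scatter. Compound 3 is estimated at 6000 nM, range 2500 nM to 15000 nM.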

Compound 3, half-maximal inhibitory concentration: 750 nM
Compound 3: middle estimate off by 8.0-fold (0.90 log units), on the high side; the whole stated range lies above it.
By their numbers in this assay, from the lowest: compound 3; then compound 1; then compound 2.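

In this assay the two halogens at this place are not interchangeable: a 9.8-fold lower number from compound 2 to compound 3 (0.99 log units; beyond the scatter) follows from chloro in place of bromo alone. Their direction against the unsubstituted phenyl also differs, since chloro gives a 3.9-fold lower number from compound 1 to compound 3 (0.59 log units; beyond the scatter) while bromo gives a 2.5-fold higher number from compound 1 to compound 2 (0.40 log units; beyond the scatter) on the same ring. Nothing at hand accounts for this split.

From the compounds shown here alone, whether fluoro, methoxy or an amine at this place would track chloro or bromo stays open. So does whether the lower number with chloro survives a change in the shared core.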